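This account rests on a few compounds, and the source may have more. Where it says the series, first, only, none or still open, it means among the compounds named here.

In an ADME assay on L6 cells (Rattus norvegicus) for cytotoxicity (a lower number here means a stronger inhibitor, a higher number a weaker inhibitor), compound 1 `Cn1[nH]c(=O)c2cc([N+](=O)[O-])ccc21` reads > 517000 nM, which is a limit of the assay and not a number. Among the compounds with values here, compound 2 `Cn1c2ccc([N+](=O)[O-])cc2c(=O)n1Cc1ccccc1` gives 43400 nM, so it holds the only actual number so far. Within the data shown here, the single measured step, an at least 11-fold lower number from compound 1 to compound 2 (1.07 log units; beyond the scatter), is large and came with benzyl in place of hydrogen on an aromatic nitrogen.

Compound 3 `Cn1c2ccc([N+](=O)[O-])cc2c(=O)n1-c1ccccc1` has not yet been measured. It changes that same group, with phenyl in place of benzyl on an aromatic nitrogen, next to the ring atom that bears a methyl group: phenyl in place of benzyl on an aromatic nitrogen.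

Among the measured compounds shown here, only one measured step bears on this change, and it is an imperfect guide. It compared hydrogen with benzyl, not two ring-bearing groups. Compound 2 moved by an at least 11-fold lower number from compound 1 to compound 2 (1.07 log units; beyond the scatter) when its benzyl replaced hydrogen, whereas compound 3 keeps a six-membered aromatic ring of carbon only on that nitrogen. On these data alone, a change of that earlier size is therefore not expected in this assay, and the direction remains open. The expected change is a 1.1-fold lower number from compound 2 to compound 3 (0.04 log units; within the scatter). For compound 3, the estimated value is 40000 nM, with an expected range of 13000 nM to 130000 nM.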

Compound 3, half-maximal inhibitory concentration: 66500 nM
Estimate against measurement, compound 3: 1.7-fold (0.22 log units) below, and the stated range covers the measured number.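

In this assay, phenyl in place of benzyl on the aromatic nitrogen gives a 1.5-fold higher number from compound 2 to compound 3 (0.19 log units; within the scatter), so this change leaves no readable difference between the two groups at this position. Phenyl also separates from hydrogen, with an at least 7.7-fold lower number from compound 1 to compound 3 (0.89 log units; beyond the scatter), which shows that the earlier shift away from hydrogen is not unique to benzyl: both groups carrying a six-membered aromatic ring of carbon only give lower numbers than the hydrogen compound. The size of that shift stays a bound and not a measured difference, because compound 1 stands at a limit of the assay and not at a number: the limit of > 517000 nM in this assay, at which 1 of the 3 values shown sits.

The compounds shown cannot separate an effect of the aromatic ring from an effect of simply replacing hydrogen, since a plain ethyl group or a longer alkyl chain without a ring does not appear among them. On these data alone, the rest of the shared core stays the same in all three compounds, and the phenyl ring carries no further group, so it remains open how a carboxylic acid or an amine on that ring would read.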